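Aryl variation on a beta-lactam series: compound 4

The compounds below may be only part of what the source reports. "The series", "measured", "known", "first", "only" and "open" are said of these compounds alone.

Measured compounds in a functional assay on MDA-MB-231 cells (Homo sapiens) for antiproliferative activity, read by MTT assay, with a stated time of 48 h; a higher number here means a weaker inhibitor, a lower number a stronger inhibitor:
- compound 1 `COC(=O)/C(=C/c1ccccc1)CN1C(=O)[C@@H](OC)[C@H]1c1ccc(Cl)cc1` gives 15600 nM
- compound 2 `COC(=O)/C(=C/c1ccccc1)CN1C(=O)[C@@H](OC)[C@H]1c1cccc(C(F)(F)F)c1` gives 18200 nM
- compound 3 `COC(=O)/C(=C/c1ccccc1)CN1C(=O)[C@@H](OC)[C@H]1c1cccc(F)c1` gives 34400 nM

Compound 3 has the highest number of the three; its gap to compound 2 lies within the scatter, and only a 2.2-fold higher number from compound 1 to compound 3 (0.34 log units; beyond the scatter) is beyond it. Compound 4 `COC(=O)/C(=C/c1ccccc1)CN1C(=O)[C@@H](OC)[C@H]1c1ccccc1` differs from compound 3 in one place: hydrogen in place of fluoro on an aromatic carbon. Going by the values given here, no measured step removes a substituent outright; the nearest comparisons are a 1.9-fold higher number from compound 2 to compound 3 (0.28 log units; within the scatter) and a 2.2-fold higher number from compound 1 to compound 3 (0.34 log units; beyond the scatter), both small. The change to a bare phenyl gives no ground for a large step in this assay, so none beyond the scatter is expected, with the number for compound 4 estimated at 40000 nM (range 18000 nM to 90000 nM), a step of a 1.2-fold higher number from compound 3 to compound 4 (0.07 log units; within the scatter).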

Compound 4, half-maximal inhibitory concentration: 11100 nM
For compound 4 the middle estimate is 3.6-fold (0.56 log units) above the measured one; measured number outside the range, below it.
By their numbers in this assay, from the lowest: compounds 4, 1, 2 and 3 (each within the scatter of the next, the first and the last beyond it).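

Hydrogen in place of fluoro is a step beyond the scatter in this assay (a 3.1-fold lower number from compound 3 to compound 4 (0.49 log units; beyond the scatter)), so a substituent on this aromatic ring is not required for the activity seen in this series. Hydrogen in place of trifluoromethyl (a 1.6-fold lower number from compound 2 to compound 4 (0.21 log units; within the scatter)) and hydrogen in place of chloro (a 1.4-fold lower number from compound 1 to compound 4 (0.15 log units; within the scatter)) both stay within the scatter, so only the fluoro compound separates from the bare phenyl. Nothing available explains this step. Going by these compounds, whether an amine or a carboxylic acid on this ring would separate from hydrogen remains open. Also open, on these data alone, is whether fluoro elsewhere on the ring would give the same step.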